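Chain Lengthening on a Second Core: A Cytotoxicity Outlook

The compounds below may be only part of what the source reports. "The series", "measured", "known", "first", "only" and "open" are said of these compounds alone.

Compound 1, `CCCCCCCc1cc2cn(COCCO)c(O)nc-2n1`, gives 119000 nM in a functional assay on HEL cells (Homo sapiens); on this read-out higher numbers stand for lower toxicity in this test and lower numbers for higher toxicity in this test.
Compound 2, `CCCCCCCCc1cc2cn(COCCO)c(O)nc-2n1`, gives 65000 nM in this assay.
Compound 3, `CCCCCc1cc2cn(COCCO)c(=O)nc2o1`, reports only a limit in this assay, namely > 200000 nM, and this is a limit of the assay and not a number.

Compounds 1 and 2 share one core, while compound 3 carries another; the difference between the two cores is not broken down here. Compound 2 differs from compound 1 by methyl in place of hydrogen on a saturated chain carbon, seven bonds along the chain from an aromatic carbon, and this step gave a 1.8-fold lower number from compound 1 to compound 2 (0.26 log units; within the scatter). Compound 4, `CCCCCCc1cc2cn(COCCO)c(=O)nc2o1`, has not yet been measured. It differs from compound 3 by methyl in place of hydrogen on a saturated chain carbon, five bonds along the chain from an aromatic carbon. Within the data shown here, this is the same kind of change as the one between compound 1 and compound 2, not the same change: in compound 1 the methyl enters seven bonds along the chain from an aromatic carbon, whereas in compound 3 it enters five bonds along the chain from an aromatic carbon. Compound 3 itself sits at the limit of > 200000 nM in this assay, at which 1 of the 3 values shown sits, so the starting point is only known as a limit.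

The step to compound 4 is expected to be small, an at least 1.1-fold lower number from compound 3 to compound 4 (0.04 log units; that floor lies within the scatter), because the same kind of change gave a 1.8-fold lower number from compound 1 to compound 2 (0.26 log units; within the scatter). Compound 4 is therefore expected to give about 180000 nM, most likely between 90000 nM and 400000 nM, with a real chance that the assay again reports only a limit.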

Compound 4, half-maximal cytotoxic concentration: > 200000 nM
Compound 4: only a limit was reported (the forecaster's own chance of this, stated with the estimate: 55%); at least 1.1-fold (0.04 log units) between middle value and limit.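

In this assay, compound 3 and compound 4 both end at a limit of the assay rather than at a number, and no step between these two compounds can be read: the limit of > 200000 nM in this assay, at which 2 of the 4 values shown sit.

The compounds shown leave open how far methyl in place of hydrogen at this place shifts the number on the core of compound 3, and whether any such shift exists at all.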